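Removing a Chloro Group: What to Expect for Compound 4

The source may hold more compounds than are shown below. What is called first, only, known or untested is meant among the compounds shown, and "the series" means these compounds.

Of the compounds shown here, three sharing one core have been tested in a functional assay on NCI-H460 cells (Homo sapiens) for inhibition, read by MTT assay, with a stated time of 72 h; on this read-out lower numbers stand for stronger inhibition and higher numbers for weaker inhibition. Compound 1 `CCN(CC)CCCn1c(=O)c(=Cc2ccccc2O)s/c1=C1\C(=O)Nc2ccc(C)cc21` gives 11300 nM. Compound 2 `CCN(CC)CCCn1c(=O)c(=Cc2ccc(F)cc2F)s/c1=C1\C(=O)Nc2ccc(Cl)cc21` gives 6100 nM. Compound 3 `CCN(CC)CCCn1c(=O)c(=Cc2cc(OC)c(OC)c(OC)c2)s/c1=C1\C(=O)Nc2ccc(Cl)cc21` gives 2990 nM. Among these three numbers compound 2 stands second highest: compound 1 lies within the usual scatter of it, while compound 3 lies beyond the scatter. For the measured compounds named here, the one directly comparable step, a 2.0-fold lower number from compound 2 to compound 3 (0.31 log units; beyond the scatter), swaps the aryl group on the double-bonded chain carbon and is modest in size.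

Compound 4 `CCN(CC)CCCn1c(=O)c(=Cc2ccc(F)cc2F)s/c1=C1\C(=O)Nc2ccccc21` is not yet measured. It differs from compound 2 by hydrogen in place of chloro on an aromatic carbon. Going by the values given here, no measured step touches this position: compound 1 carries a methyl group there, but it also bears a different aryl group on the chain carbon, so its value cannot be separated into two contributions. Among the compounds with values here, the only measured step, from compound 2 to compound 3, concerns another part of the molecule and was modest. With nothing pointing to a change at this position, the expectation for the step from compound 2 to compound 4 in this assay is a 1.2-fold higher number from compound 2 to compound 4 (0.09 log units; within the scatter), which is no shift beyond the scatter. Compound 4 is therefore estimated at 7500 nM, with a range from 3000 nM to 20000 nM.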

Compound 4, half-maximal inhibitory concentration: 5470 nM
For compound 4 the middle estimate is 1.4-fold (0.14 log units) above the measured one, within the range that was stated.
By their numbers in this assay, from the lowest: compounds 3, 4, 2 and 1 (each within the scatter of the next, the first and the last beyond it).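

Taking the chloro group off the aromatic carbon gives the first direct reading of this position, since the 2,4-difluorophenyl group stays the same and only one heavy atom leaves: in this assay the result is a 1.1-fold lower number from compound 2 to compound 4 (0.05 log units; within the scatter). Chloro is therefore not required at this position for the inhibition seen with compound 2, and hydrogen serves equally well within the usual scatter of the measurement, whereas the change of aryl group, a 2.0-fold lower number from compound 2 to compound 3 (0.31 log units; beyond the scatter), remains the only single-place step that lies beyond that scatter. No supporting evidence is available that could explain why this position tolerates the exchange.

As far as these compounds go, it remains open whether chloro and hydrogen would also match when the chain carbon carries the 3,4,5-trimethoxyphenyl group of compound 3, and the methyl group of compound 1 still cannot be judged alone, as that compound also has a different aryl group. Nor do these compounds show how this position would respond to a larger or quite different group, such as an amine, a carboxylic acid or a nitrile.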